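The compounds below may be only part of what the source reports. "The series", "measured", "known", "first", "only" and "open" are said of these compounds alone.

Compound 1 `CCSCCc1c[nH]c2ccc(F)cc12` in an assay on isolated protein (urine) for inhibition of Myeloperoxidase (Homo sapiens), with a stated time of 5 min (on this read-out higher numbers stand for weaker inhibition and lower numbers for stronger inhibition), gives > 100 nM, a limit of the assay and not a number.
Compound 2 `NC(=O)CCCc1c[nH]c2ccc(F)cc12` in this assay gives 18 nM.

Compound 2 holds the only number shown; the other value shown is a limit. Among the compounds with values here, the one measured step is an at least 5.5-fold lower number from compound 1 to compound 2 (0.74 log units; beyond the scatter), and that change sits on a saturated chain carbon, not on the amide nitrogen. Compound 3 `CCNC(=O)CCCc1c[nH]c2ccc(F)cc12` differs from compound 2 by ethyl in place of hydrogen on an amide-type nitrogen. Within the data shown here, no measured step touches an amide-type nitrogen, so the measured step bears on this change only weakly, and a direction cannot be read from it. Compound 3 is therefore expected to stay within the scatter of compound 2 in this assay, with a 1.4-fold higher number from compound 2 to compound 3 (0.14 log units; within the scatter) meaning no change beyond the scatter. The estimate for compound 3 is 25 nM, in the range 8 nM to 80 nM.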

Compound 3, half-maximal inhibitory concentration: 182 nM
Compound 3: middle estimate off by 7.3-fold (0.86 log units), on the low side, outside the stated range (above it).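

The amide-type nitrogen of compound 2 proves sensitive in this assay: ethyl in place of hydrogen there gives a 10-fold higher number from compound 2 to compound 3 (1.00 log units; beyond the scatter). Within the data shown here, this is the first measured change at that nitrogen, and it shows that, from compound 2, the amide hydrogen cannot be exchanged for ethyl without weaker inhibition on this read-out. The step between compound 1 and compound 3 cannot be read, because compound 1 stands at a limit of the assay and not at a number: the limit of > 100 nM in this assay, at which 1 of the 3 values shown sits.

The compounds shown leave open whether a methyl group on this nitrogen would read closer to compound 2 or to compound 3, and so whether the rise belongs to ethyl in particular or to any replacement of the amide hydrogen. They also leave open how a carboxylic acid in place of the carbamoyl group would read.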